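Swapping Methoxy for Nitro on a Shared Core

This account rests on a few compounds, and the source may have more. Where it says the series, first, only, none or still open, it means among the compounds named here.

Of the compounds shown here, three have been measured in an assay on membranes from brain for displacement of a labelled ligand from Sigma non-opioid intracellular receptor 1 (Cavia porcellus), read by scintillation counting, with a stated time of 120 min; a lower number here means a stronger inhibitor, a higher number a weaker inhibitor. Compound 1 `COc1ccc(-c2scc3c2CCOC32CCN(Cc3ccccc3)CC2)cc1` gives 1.5 nM in this assay. Compound 2 `O=[N+]([O-])c1ccc(-c2scc3c2CCOC32CCN(Cc3ccccc3)CC2)cc1` carries the difference nitro in place of methoxy on an aromatic carbon and gives 1.7 nM in this assay; the step between them is a 1.1-fold higher number from compound 1 to compound 2 (0.05 log units; within the scatter). Compound 3 `COc1ccc(-c2scc3c2CC(OC)OC32CCN(Cc3ccccc3)CC2)cc1` differs from compound 1 in another part of the molecule, namely (methoxy in place of hydrogen on a saturated ring carbon); in this assay compound 3 gives 2.2 nM, and that step is a 1.5-fold higher number from compound 1 to compound 3 (0.17 log units; within the scatter). All three numbers lie within the usual scatter of one another, so no order among them can be read.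

Compound 4 `COC1Cc2c(csc2-c2ccc([N+](=O)[O-])cc2)C2(CCN(Cc3ccccc3)CC2)O1` has not been measured. It differs from compound 3 by nitro in place of methoxy on an aromatic carbon, the same change that separates compound 1 from compound 2, here made on the core of compound 3 rather than on that of compound 1; the two cores differ in the way already described for compound 3 against compound 1. Because the earlier step was a 1.1-fold higher number from compound 1 to compound 2 (0.05 log units; within the scatter), which lies within the scatter, a step of about a 1.1-fold higher number from compound 3 to compound 4 (0.04 log units; within the scatter) is expected for the same change on the second core, again within the scatter. This expectation rests on a single earlier pair, compound 1 and compound 2, and on nothing more. Compound 4 is therefore estimated at 2.4 nM, with a range from 1.2 nM to 5 nM.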

Compound 4, inhibition constant: 1 nM
Beside the measured number, compound 4's estimate is 2.4-fold (0.38 log units) above it; the whole stated range lies above it.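

On the core of compound 3, going from 4-methoxyphenyl to 4-nitrophenyl gives a 2.2-fold lower number from compound 3 to compound 4 (0.34 log units; beyond the scatter) in this assay, a modest step that stands clear of the scatter, unlike the same change on the core of compound 1. Even so, the gap between the two steps is no larger than two such steps can show by scatter alone, so these data neither show that the change behaves differently on the two cores nor prove that it carries over unaltered: the same change on two cores in this assay, a 1.1-fold higher number (0.05 log units; within the scatter) from compound 1 to compound 2 and a 2.2-fold lower number (0.34 log units; beyond the scatter) from compound 3 to compound 4, 2.5-fold (0.40 log units) apart, within the scatter of two such steps The methoxy on the saturated ring carbon reads the same way, with a 1.7-fold lower number from compound 2 to compound 4 (0.23 log units; within the scatter), and with only one pair of compounds on each side, this comparison also cannot separate a real dependence between the two places from scatter: the same change on two cores in this assay, a 1.5-fold higher number (0.17 log units; within the scatter) from compound 1 to compound 3 and a 1.7-fold lower number (0.23 log units; within the scatter) from compound 2 to compound 4, 2.5-fold (0.40 log units) apart, within the scatter of two such steps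

The compounds shown leave open how other groups in place of the nitro, such as an amine, a nitrile or a chlorine, would read on either core. They also leave open whether a longer chain, such as ethoxy, in place of the methoxy on the saturated ring carbon would make any gap between the two cores easier to read.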